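Vero cell cytotoxicity: a methoxyphenyl replaces a fluorophenyl

The compounds below may be only part of what the source reports. "The series", "measured", "known", "first", "only" and "open" are said of these compounds alone.

Three compounds of the shared core have been examined in a toxicity assay on Vero cells (Chlorocebus sabaeus) for cytotoxicity; on this read-out lower numbers stand for higher toxicity in this test and higher numbers for lower toxicity in this test. Compound 1 `COc1ncc(-c2ccccc2)cc1[C@@H](c1ccccc1)[C@@](O)(CCN(C)C)c1cccc2ccccc12` gives in this assay only a limit, > 50 ug/mL. Compound 3 `COc1ncc(-c2ccccc2)cc1[C@@H](c1ccccc1)[C@@](O)(CCN(C)C)c1cccc(F)c1F` likewise gives only a limit, > 50 ug/mL. The step that the two limits leave unreadable from compound 1 to compound 3 is therefore unreadable. Compound 2 `COc1nc(-c2cccc(F)c2)ccc1[C@@H](c1ccccc1)[C@@](O)(CCN(C)C)c1cccc2ccccc12` also sits at a limit, > 50 ug/mL. It thus stands where all the measured compounds stand, at the limit of > 50 ug/mL in this assay, at which 3 of the 3 values shown sit. Compound 4 `COc1ccc(-c2ccc([C@@H](c3ccccc3)[C@@](O)(CCN(C)C)c3cccc4ccccc34)c(OC)n2)cc1` differs from compound 2 by 4-methoxyphenyl in place of 3-fluorophenyl on an aromatic carbon. Going by the values given here, no measured step resembles this change, and the one measured step cannot be read, so no step beyond the scatter is expected in this assay, and compound 4 is expected at 60 ug/mL, between 30 ug/mL and 120 ug/mL, an expected step that the limit leaves unreadable from compound 2 to compound 4.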

Compound 4, half-maximal cytotoxic concentration: > 50 ug/mL
Compound 4 gave a limit, no number; the forecaster's own chance of this, stated with the estimate: 85%; the middle value lies beyond the limit too.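

Going by these compounds alone, compound 2 and compound 4 both give only a limit in this assay and so no step between them can be read. The compounds shown leave open whether any change on the shared core shifts this read-out at all.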